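The source may hold more compounds than are shown below. What is called first, only, known or untested is meant among the compounds shown, and "the series" means these compounds.

Within the data shown here, in a functional assay on PC-3 cells (Homo sapiens) for cytotoxicity, read by MTT assay, with a stated time of 72 h (on this read-out higher numbers stand for weaker inhibition and lower numbers for stronger inhibition), compound 1 `CNC(=O)c1cc(Oc2ccc(C(=O)/C=C/c3ccccc3)cc2)ccn1` gives 3170 nM and compound 2 `CNC(=O)c1cc(Oc2ccc(C(=O)/C=C/c3ccc(F)cc3)cc2)ccn1` gives 6140 nM, which places compound 2 within the scatter of the only other measured compound. Compound 3 `CNC(=O)c1cc(Oc2ccc(C(=O)/C=C/c3ccc(OC)cc3)cc2)ccn1` keeps the shared core and differs from compound 2 by methoxy in place of fluoro on an aromatic carbon. Among the measured compounds shown here, the one measured step that bears on this change, a 1.9-fold higher number from compound 1 to compound 2 (0.29 log units; within the scatter), lies within the scatter. Nothing beyond the scatter is therefore expected in this assay, and the expected step is a 1.4-fold lower number from compound 2 to compound 3 (0.13 log units; within the scatter). Compound 3 is estimated at 4500 nM, with an expected range from 1800 nM to 11000 nM.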

Compound 3, half-maximal inhibitory concentration: > 50000 nM
Compound 3 was reported as a limit (the forecaster's own chance of this, stated with the estimate: 3%); middle value at least 11-fold (1.04 log units) from the limit.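

In this assay compound 3 is given only as a limit of the assay: the limit of > 50000 nM in this assay, at which 1 of the 3 values shown sits. Methoxy in place of fluoro gives an at least 8.1-fold higher number from compound 2 to compound 3 (0.91 log units; beyond the scatter), and methoxy in place of hydrogen gives an at least 15-fold higher number from compound 1 to compound 3 (1.19 log units; beyond the scatter), both beyond the scatter. The earlier change of hydrogen to fluoro stayed within the scatter, so only now does this position, para to a large group, prove sensitive to the group placed on it.

Going by these compounds, whether a hydroxyl, an amine or a methyl here would track fluoro or methoxy remains open. On these data alone, the true size of both steps also stays unknown.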